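A Phenyl Added to Compound 2

A few compounds are considered here, and "the series" means these few. Any claim that something is new, unique, unknown or untested is made for them only; others in the source may bear on it.

Measured in a functional assay on SK-OV-3 cells (Homo sapiens) for antiproliferative activity, read by MTT assay, with a stated time of 72 h; a lower number here means a stronger inhibitor, a higher number a weaker inhibitor:
Compound 1 `CC(C)(C)NC(=O)CCc1cccc2c1B(O)OC2`: > 100000 nM (a limit)
Compound 2 `O=C(CCc1cccc2c1B(O)OC2)Nc1ccccc1`: 200 nM
Compound 3 `CC(C)(C)OC(=O)Nc1ccc(NC(=O)CCc2cccc3c2B(O)OC3)cc1`: > 100000 nM (a limit)

Compound 2 alone has an actual number. Compound 1 and compound 3 both stand at the limit of > 100000 nM in this assay, at which 2 of the 3 values shown sit. Compound 4 `O=C(CCc1cccc2c1B(O)OC2)Nc1cccc(-c2ccccc2)c1` alters compound 2 by phenyl in place of hydrogen on an aromatic carbon. Going by the values given here, two measured steps bear on this. Phenyl in place of tert-butyl on an amide-type nitrogen gave an at least 500-fold lower number from compound 1 to compound 2 (2.69 log units; beyond the scatter), a large gain. The closer case is a substitution of the same kind, (tert-butoxycarbonyl)amino in place of hydrogen on an aromatic carbon, which gave an at least 500-fold higher number from compound 2 to compound 3 (2.69 log units; beyond the scatter), a large loss. A higher number is therefore expected, though the entering group differs, so a smaller loss seems likely. The expected change is a 10-fold higher number from compound 2 to compound 4 (1.00 log units; beyond the scatter). For compound 4 the estimate is 2000 nM, with an expected range of 150 nM to 50000 nM.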

Compound 4, half-maximal inhibitory concentration: 250 nM
Compound 4: middle estimate off by 8.0-fold (0.90 log units), on the high side; the range from low to high includes it.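

Phenyl in place of hydrogen on this aromatic carbon gave a 1.3-fold higher number from compound 2 to compound 4 (0.10 log units; within the scatter), so this added ring leaves the antiproliferative effect in place. A group added to this aromatic ring therefore need not bring the large loss seen with the (tert-butoxycarbonyl)amino group of compound 3. Only compound 2 and compound 4 can be compared as actual numbers, because the other two compounds stand at a limit: the limit of > 100000 nM in this assay, at which 2 of the 4 values shown sit.

Going by these compounds, whether an amine or a carboxylic acid on this same carbon would be accepted as well stays open. So does the effect of phenyl on the ring's other carbons.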